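The compounds below may be only part of what the source reports. "The series", "measured", "known", "first", "only" and "open" are said of these compounds alone.

In a physicochemical assay for lipophilicity, using the shake flask method, in phosphate buffer, measured as octanol-water partition, with a stated time of 1 h, at pH 7.4 (a lower number here means a more polar compound, a higher number a more lipophilic compound), compound 1 `CCNC(=O)Nc1cc(Cl)c(-c2cncc(C(=O)O)c2)cn1` gives -1.1, compound 2 `CCNC(=O)Nc1cc(Br)c(-c2cncc(C(=O)O)c2)cn1` gives -1 and compound 3 `CCNC(=O)Nc1cc(-c2ccncc2)c(-c2cncc(C(=O)O)c2)cn1` gives -0.82, so compound 3 stands within the scatter of both others. Compound 4 `CCNC(=O)Nc1cc(-c2nc(C(C)(C)C)cs2)c(-c2cncc(C(=O)O)c2)cn1` has not been measured, and its difference from compound 3 is this: 4-(tert-butyl)-1,3-thiazol-2-yl in place of pyridin-4-yl on an aromatic carbon. Three measured steps at this same place bear on it: a number 0.10 log units higher from compound 1 to compound 2 (within the scatter), a number 0.28 log units higher from compound 1 to compound 3 (within the scatter) and a number 0.18 log units higher from compound 2 to compound 3 (within the scatter). All three are small, yet 4-(tert-butyl)-1,3-thiazol-2-yl carries more heavy atoms than pyridin-4-yl, so these steps only loosely guide the expectation. The expected change, upward and beyond the scatter, is a number 1.02 log units higher from compound 3 to compound 4 (beyond the scatter). Compound 4 is estimated at 0.2, within a range of -0.4 to 0.9.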

Compound 4, distribution coefficient: 0.12
Compound 4: the middle estimate sits 0.08 log units above what was measured; the range from low to high includes it.
By their numbers in this assay, from the lowest: compounds 1, 2 and 3 (each within the scatter of the next); then compound 4.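

In this assay this position can move the number beyond the scatter: with 4-(tert-butyl)-1,3-thiazol-2-yl as the entering group, the steps are a number 0.94 log units higher from compound 3 to compound 4 (beyond the scatter) and a number 1.12 log units higher from compound 2 to compound 4 (beyond the scatter) and also a number 1.22 log units higher from compound 1 to compound 4 (beyond the scatter) at this one place. Chloro, bromo and pyridin-4-yl stood within the scatter of one another, so compound 4 is the first to separate from the rest. No measurement at hand accounts for the step.

From the compounds shown here alone, whether the step follows the tert-butyl group or the five-membered aromatic ring remains open. So does what an amine or a longer alkyl chain would give at this place.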